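The source may hold more compounds than are shown below. What is called first, only, known or untested is meant among the compounds shown, and "the series" means these compounds.

Compound 3 `COc1ccc(SCc2ccc(C(=O)Nc3ccccc3N)cc2)cc1` is one of three benzamide-type compounds examined in a functional assay on HCT-116 cells (Homo sapiens) for antiproliferative activity, read by CCK-8 assay, with a stated time of 72 h; on this read-out lower numbers stand for stronger inhibition and higher numbers for weaker inhibition. In this assay compound 3 gives 1640 nM, the larger of the two numbers obtained, yet within the scatter of compound 1 `Nc1ccccc1NC(=O)c1ccc(CSc2nccc(C(F)(F)F)n2)cc1`, which gives 1140 nM. For compound 2 `Nc1ccccc1NC(=O)/C=C/c1ccc(CSc2ccc(F)cc2)cc1` the result is recorded as "not determined" (no result reported), so no number is available. Compound 4 `Cc1ccc(SCc2ccc(C(=O)Nc3ccccc3N)cc2)cc1` differs from compound 3 in one place: methyl in place of methoxy on an aromatic carbon. Going by the values given here, no measured pair shows the effect of this change here, and nothing in the data points in either direction. The step from compound 3 to compound 4 is therefore expected to stay within the scatter, namely a 1.1-fold lower number from compound 3 to compound 4 (0.04 log units; within the scatter). Compound 4 is estimated at 1500 nM, with a range from 600 nM to 4000 nM.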

Compound 4, half-maximal inhibitory concentration: 2630 nM
Beside the measured number, compound 4's estimate is 1.8-fold (0.24 log units) below it; the range from low to high includes it.
By their numbers in this assay, from the lowest: compounds 1, 3 and 4 (each within the scatter of the next, the first and the last beyond it).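

In this assay, going by these compounds alone, exchanging 4-methoxyphenyl for 4-methylphenyl gives a 1.6-fold higher number from compound 3 to compound 4 (0.21 log units; within the scatter), the only measured step at this position, para to a large group. Removing the oxygen and its hydrogen-bond acceptor therefore leaves a difference that cannot be told apart from the scatter of repeated measurements. Nothing available here bears on this result. The compounds shown leave open how this position responds to a group such as an amine, a carboxylic acid or a longer chain such as ethoxy.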